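The source may report more compounds than this note shows. Statements on the series, on what has been measured and on what is new or still open speak of the compounds shown alone.

Measured compounds:
compound 1 `Cc1nn(-c2ncnc3nc[nH]c23)c2c1C(OC1CCCC1)CC(=O)N2` — in a functional assay on HEK293 cells for agonist activity at G-protein coupled receptor 39 (Homo sapiens), read by scintillation proximity assay and inositol phosphate accumulation, with a stated time of 75 min, in the presence of a further agent that is not named here (on this read-out lower numbers stand for an effect already at smaller amounts and higher numbers for an effect only at larger amounts of compound), compound 1 gives 2 nM
compound 2 `Cc1nn(-c2ncnc3nc[nH]c23)c2c1C(C(=O)NCc1ccccc1)CC(=O)N2` — in this assay compound 2 gives 5 nM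

Compound 2 holds the higher of the two numbers; the step of a 2.5-fold higher number from compound 1 to compound 2 (0.40 log units; beyond the scatter) separates it from compound 1. Compound 3 `Cc1nn(-c2ncnc3nc[nH]c23)c2c1C(c1ccc(OC(C)C)cc1)CC(=O)N2` differs from compound 2 by 4-isopropoxyphenyl in place of benzylcarbamoyl on a saturated ring carbon. For the measured compounds named here, only the step from compound 1 to compound 2 touches this position, and it is modest; no measured step exchanges benzylcarbamoyl for an aryl group, so the direction is open. A change of about a 1.3-fold lower number from compound 2 to compound 3 (0.10 log units; within the scatter) in this assay is expected, within or near the scatter. Compound 3 is estimated at 4 nM, range 1.5 nM to 12 nM.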

Compound 3, half-maximal effective concentration: 18 nM
Beside the measured number, compound 3's estimate is 4.5-fold (0.65 log units) below it, and the stated range ends below it.
By their numbers in this assay, from the lowest: compound 1; then compound 2; then compound 3.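

In this assay, the saturated ring carbon tolerates a directly attached aryl group, but at a cost beyond the scatter: a 3.6-fold higher number from compound 2 to compound 3 (0.56 log units; beyond the scatter) and a 9.0-fold higher number from compound 1 to compound 3 (0.95 log units; beyond the scatter). Benzylcarbamoyl and 4-isopropoxyphenyl have the same heavy-atom count and each has one six-membered aromatic ring, so matching these counts does not preserve the number. Nothing available explains the shift.

The compounds shown leave open whether the higher number follows the aryl ring itself or its isopropoxy group. Unsubstituted phenyl, 4-methoxyphenyl or an amine at this carbon would help separate these.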